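Chloro on the phenyl ring of compound 3

The compounds below may be only part of what the source reports. "The series", "measured", "known", "first", "only" and "open" are said of these compounds alone.

In a functional assay on HepG2 cells (Homo sapiens) for antiproliferative activity, read by MTT assay, with a stated time of 48 h (on this read-out higher numbers stand for weaker inhibition and lower numbers for stronger inhibition), compound 1 (`S=c1oc(-c2ccc3c(c2)OCCO3)nn1CN1CCN(C(c2ccccc2)c2ccccc2)CC1`) gives 9120 nM as a measured number. Compound 2 (`S=c1oc(-c2ccc3c(c2)OCCO3)nn1CN1CCN(c2cccc(Cl)c2)CC1`) gives > 50000 nM as a limit of the assay and not a number. Compound 3 (`S=c1oc(-c2ccc3c(c2)OCCO3)nn1CN1CCN(c2ccccc2)CC1`) gives > 50000 nM as a limit too, so it stands without a number of its own. Going by the values given here, the series thus meets the limit of > 50000 nM in this assay, at which 2 of the 3 values shown sit, and offers a single number so far.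

Compound 4 (`S=c1oc(-c2ccc3c(c2)OCCO3)nn1CN1CCN(c2ccccc2Cl)CC1`) carries chloro in place of hydrogen on an aromatic carbon, ortho to a large group (chloro in place of hydrogen on an aromatic carbon). Among the compounds with values here, the only measured step on this kind of change is a step that the two limits leave unreadable from compound 2 to compound 3 and it hands on no size. No step beyond the scatter is therefore expected in this assay and no direction can be argued. The expected step is a number no higher from compound 3 to compound 4 (the limit leaves the size open) and will most likely read as another limit. For compound 4 the estimated value is 50000 nM with an expected range of 20000 nM to 80000 nM overall.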

Compound 4, half-maximal inhibitory concentration: 11400 nM
The estimate for compound 4 lay 4.4-fold (0.64 log units) above the measured number, outside the stated range (below it).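

In this assay, going by these compounds alone, chloro in place of hydrogen on an aromatic carbon, ortho to a large group, gives the first readable step for this change: an at least 4.3-fold lower number from compound 3 to compound 4 (0.64 log units; beyond the scatter). The 2-chlorophenyl group in place of 3-chlorophenyl gives an at least 4.3-fold lower number from compound 2 to compound 4 (0.64 log units; beyond the scatter), so among these compounds a chloro group does not give a readable gain in every place on the ring. Both sizes are lower bounds, as each step starts from a compound with no number of its own: the limit of > 50000 nM in this assay, at which 2 of the 4 values shown sit.

On these data alone, the full size of both steps stays open while compound 2 and compound 3 have only limits. As far as these compounds go, it also remains open whether fluoro, methyl or methoxy at this same place would give a step like that of chloro.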